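The compounds below may be only part of what the source reports. "The series", "measured", "known", "first", "only" and "open" are said of these compounds alone.

Measured in an ADME assay on HEK-293T cells (Homo sapiens) for cytotoxicity, read by CCK-8 assay, with a stated time of 48 h; on this read-out lower numbers stand for stronger inhibition and higher numbers for weaker inhibition:

compound 1 `O=[N+]([O-])c1cccc(NC(=S)NCCNS(=O)(=O)c2ccc(-c3ccccc3OCc3ccccc3)s2)c1`: 18300 nM
compound 2 `O=C(NCCNS(=O)(=O)c1ccc(-c2ccccc2OCc2ccccc2)s1)Nc1cccc([N+](=O)[O-])c1`: 13300 nM
compound 3 `Cc1ccc(-c2ccsc2S(=O)(=O)NCCNC(=S)Nc2cccc([N+](=O)[O-])c2)c(Oc2ccc(O)c(O)c2)c1`: 7900 nM

Compound 1 and compound 3 carry different cores; the difference between the two cores is not broken down here. Within the core of compound 1, the change a group of 12 heavy atoms (7 carbon, 2 nitrogen, 3 oxygen; one six-membered aromatic ring of carbon only) in place of a group of 12 heavy atoms (7 carbon, 2 nitrogen, 2 oxygen, 1 sulfur; one six-membered aromatic ring of carbon only), on an amine nitrogen gives a 1.4-fold lower number from compound 1 to compound 2 (0.14 log units; within the scatter). Compound 3 and compound 2 lie within the scatter of each other, and only the gap between compound 3 and compound 1 stands beyond it, so no order among the three is claimed.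

Compound 4 `Cc1ccc(-c2ccsc2S(=O)(=O)NCCNC(=O)Nc2cccc([N+](=O)[O-])c2)c(Oc2ccc(O)c(O)c2)c1` has not been measured. It differs from compound 3 by a group of 12 heavy atoms (7 carbon, 2 nitrogen, 3 oxygen; one six-membered aromatic ring of carbon only) in place of a group of 12 heavy atoms (7 carbon, 2 nitrogen, 2 oxygen, 1 sulfur; one six-membered aromatic ring of carbon only), on an amine nitrogen, the same change, on the same kind of place, as the one already seen on the core of compound 1. Compound 4 is expected to show a 1.4-fold lower number from compound 3 to compound 4 (0.13 log units; within the scatter) in this assay, because the same change gave a 1.4-fold lower number from compound 1 to compound 2 (0.14 log units; within the scatter). That expectation rests on a single measured pair on a different core, so the range is kept wide. Compound 4 is estimated at 5800 nM, between 2500 nM and 13000 nM.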

Compound 4, half-maximal inhibitory concentration: 6800 nM
The estimate for compound 4 lay 1.2-fold (0.07 log units) below the measured number; low and high end bracket the measured number.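

Notes on the change at the amine nitrogen: in this assay, placing the (3-nitrophenyl)carbamoyl group where the sulfur-bearing group of the same size stood gives a 1.2-fold lower number from compound 3 to compound 4 (0.07 log units; within the scatter) on the core of compound 3, so the second core repeats what was seen on the first. Set side by side, the two steps agree: the same change on two cores in this assay, a 1.4-fold lower number (0.14 log units; within the scatter) from compound 1 to compound 2 and a 1.2-fold lower number (0.07 log units; within the scatter) from compound 3 to compound 4, 1.2-fold (0.07 log units) apart, within the scatter of two such steps. This shows that, on these two cores, the change carries over without a step that stands out from the scatter; it does not show that the change lowers the number on either core, since neither step lies beyond the scatter, and two pairs establish no rule for the series.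

The compounds shown leave open how the number responds when the nitro group gives way to a nitrile or an amine, or when the saturated chain on the amine nitrogen becomes a longer chain. From the compounds shown here alone, whether the same small step would hold on a third core also remains open.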